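From fluoro to cyano on the aromatic ring

The source may report more compounds than this note shows. Statements on the series, on what has been measured and on what is new or still open speak of the compounds shown alone.

Measured so far in a physicochemical assay for lipophilicity; on this read-out higher numbers stand for higher lipophilicity and lower numbers for lower lipophilicity:
- Compound 1 `COc1ccc(C2=NO[C@]3(C2)C(=O)O[C@@H]2[C@H]3CC[C@H](C)[C@]3(O)C=CC(=O)[C@@]23C)cc1` gives 1.47
- Compound 2 `C[C@H]1CC[C@@H]2[C@@H](OC(=O)[C@]23CC(c2ccc(O)cc2)=NO3)[C@]2(C)C(=O)C=C[C@@]12O` gives 0.932
- Compound 3 `C[C@H]1CC[C@@H]2[C@@H](OC(=O)[C@]23CC(c2ccc(F)cc2)=NO3)[C@]2(C)C(=O)C=C[C@@]12O` gives 1.58

Compound 3 at 1.58 cannot be told apart from compound 1 and stands beyond the scatter above compound 2. The next compound, compound 4 `C[C@H]1CC[C@@H]2[C@@H](OC(=O)[C@]23CC(c2ccc(C#N)cc2)=NO3)[C@]2(C)C(=O)C=C[C@@]12O`, has cyano in place of fluoro on an aromatic carbon. Two measured swaps on that aromatic carbon offer a guide. One (a number 0.11 log units higher from compound 1 to compound 3 (within the scatter)) stayed within the scatter, while the other (a number 0.65 log units higher from compound 2 to compound 3 (beyond the scatter)) was modest. Neither involves cyano, so the guide is loose. In this assay I expect a modest step down, a number 0.48 log units lower from compound 3 to compound 4 (beyond the scatter) by estimate. Compound 4 is thus estimated at 1.1 with 0.75 to 1.45 as the expected range.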

Compound 4, partition coefficient: 1.17
For compound 4 the middle estimate is 0.07 log units below the measured one; low and high end bracket the measured number.
By their numbers in this assay, from the lowest: compounds 2, 4, 1 and 3 (each within the scatter of the next, the first and the last beyond it).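

In this assay, replacing fluoro with cyano at this aromatic carbon gives a clear change: a number 0.41 log units lower from compound 3 to compound 4 (beyond the scatter). Cyano cannot be told apart from either hydroxy, a number 0.24 log units higher from compound 2 to compound 4 (within the scatter), or methoxy, a number 0.30 log units lower from compound 1 to compound 4 (within the scatter), even though hydroxy and fluoro do differ from each other. No available evidence explains these steps. Still open, on these data alone, is where an amine or a carboxylic acid at this position would fall relative to these four groups. Also open, as far as these compounds go, is whether the same swaps would give similar steps on a different core.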